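Aryl variation on the triazole nitrogen; cytotoxicity in liver cells

The source may report more compounds than this note shows. Statements on the series, on what has been measured and on what is new or still open speak of the compounds shown alone.

Working notes on a small set built on a shared spiro core. Compound 1 is `CCc1cccc(C)c1-n1nncc1CN1C(=O)C2(C(C#N)=C(N)Oc3c(N)cc4nc5ccccc5nc4c32)c2ccccc21`. Compound 2 is `Cc1cc(C)cc(-n2nncc2CN2C(=O)C3(C(C#N)=C(N)Oc4c(N)cc5nc6ccccc6nc5c43)c3ccccc32)c1`. Compound 3 is `Cc1ccc(Cl)cc1-n1nncc1CN1C(=O)C2(C(C#N)=C(N)Oc3c(N)cc4nc5ccccc5nc4c32)c2ccccc21`. All three were tested in an ADME assay on L02 cells (Homo sapiens) for antiproliferative activity, read by MTT assay, with a stated time of 48 h; a higher number here means a weaker inhibitor, a lower number a stronger inhibitor. In this assay compound 1 gives > 50000 nM, which is a limit of the assay and not a number. Compound 2 likewise gives > 50000 nM, a limit. Compound 3 also gives > 50000 nM, again a limit. The three steps among them, a step that the two limits leave unreadable from compound 1 to compound 2, a step that the two limits leave unreadable from compound 1 to compound 3 and a step that the two limits leave unreadable from compound 2 to compound 3, therefore cannot be read for size, as the limit of > 50000 nM in this assay, at which 3 of the 3 values shown sit, shows.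

Compound 4, `N#CC1=C(N)Oc2c(N)cc3nc4ccccc4nc3c2C12C(=O)N(Cc1cnnn1-c1ccc(Cl)cc1[N+](=O)[O-])c1ccccc12`, has not yet been measured. It differs from compound 3 by 4-chloro-2-nitrophenyl in place of 5-chloro-2-methylphenyl on an aromatic nitrogen. For the measured compounds named here, only the steps just named bear on this change, and none of them gives a readable size; nothing in the measured set shows any aryl variation on the triazole nitrogen moving a value off the limit. Compound 4 is therefore expected to stay at or close to the limit in this assay, with an estimated step that the limit leaves unreadable from compound 3 to compound 4. The estimated value for compound 4 is 70000 nM, within a range from 25000 nM to 200000 nM.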

Compound 4, half-maximal inhibitory concentration: > 50000 nM
Compound 4 gave a limit, no number; the forecaster's own chance of this, stated with the estimate: 80%; the middle value does not contradict the limit.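

Compound 4 gives > 50000 nM in this assay, a limit and not a number. The steps to compound 4 from compound 1, compound 2 and compound 3 therefore cannot be read for size: the limit of > 50000 nM in this assay, at which 4 of the 4 values shown sit.

The compounds shown leave open whether any aryl group on the triazole nitrogen of the shared core gives a readable value in this assay.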